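Aryl swaps on the hydrazone carbon of the shared core

The source may report more compounds than this note shows. Statements on the series, on what has been measured and on what is new or still open speak of the compounds shown alone.

Among the compounds with values here, the series so far holds two measured compounds with the same core and differing aryl groups on the hydrazone carbon. Compound 1 `O=C(N/N=C/c1ccc(Cl)cc1)c1cccnc1Nc1cccc(C(F)(F)F)c1` gives 52.4% in a functional assay on the whole organism (strain Wistar) for inhibition, with Rattus norvegicus as the target, read by paw edema, with a stated time of 30 min, at a dose of 10 mg/kg by the intraperitoneal route; a lower number here means less inhibition, a higher number more inhibition at the dose given (going by the name of the read-out). Compound 2 `O=C(N/N=C/c1ccc(O)c(O)c1)c1cccnc1Nc1cccc(C(F)(F)F)c1` gives 51.4% in this assay. Compound 2 has the lower of the two numbers, but only by a small margin: the step of a number 1 percentage points lower from compound 1 to compound 2 (within the scatter) stays inside the scatter, so the two compounds cannot be told apart on this read-out.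

Compound 3 `COc1ccc(/C=N/NC(=O)c2cccnc2Nc2cccc(C(F)(F)F)c2)c(OC)c1` is not yet measured. Its difference from compound 2 is 2,4-dimethoxyphenyl in place of 3,4-dihydroxyphenyl on a carbon with a double bond to nitrogen. Within the data shown here, the only measured step that bears on it is the one between compound 1 and compound 2, which also exchanged the aryl group on the carbon with a double bond to nitrogen and amounted to a number 1 percentage points lower from compound 1 to compound 2 (within the scatter). On that basis no step beyond the scatter is expected from compound 2 to compound 3 in this assay, and the expected step of a number 1.4 percentage points lower from compound 2 to compound 3 (within the scatter) is correspondingly small. Compound 3 is therefore estimated to give 50% in this assay, with a range from 38% to 62%.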

Compound 3, a percentage reported as inhibition, in the whole organism at one dose (the size of the read-out at that dose, not a potency): 37.8%
Beside the measured number, compound 3's estimate is 12.2 percentage points above it, outside the stated range (below it).
By their numbers in this assay, from the lowest: compound 3; then compounds 2 and 1 (each within the scatter of the next).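

The aryl group on the carbon with a double bond to nitrogen is not silent in this assay: the entry of 2,4-dimethoxyphenyl brings a number 13.6 percentage points lower from compound 2 to compound 3 (beyond the scatter) and a number 14.6 percentage points lower from compound 1 to compound 3 (beyond the scatter) in the two exchanges now available. Compounds 1 and 2 remain within the scatter of each other, so this position accepts 4-chlorophenyl and 3,4-dihydroxyphenyl without a readable difference, while 2,4-dimethoxyphenyl stands apart from both; the loss of hydrogen-bond donors on going from 3,4-dihydroxyphenyl does not serve as a pattern, since 4-chlorophenyl also has no hydroxyl groups and goes against it. No measured evidence is at hand to account for the step.

The exchange from compound 2 to compound 3 alters both the kind of oxygen substituent and the substitution pattern in the name, so 3,4-dimethoxyphenyl would be the group that separates the two. From the compounds shown here alone, how an aryl group bearing a dimethylamino group or a carboxylic acid would read at this position, and whether a single methoxy group would behave like two, also stays open.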